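From Allyl to 2-Cyanoethyl: Expectation for Compound 4

The source may report more compounds than this note shows. Statements on the series, on what has been measured and on what is new or still open speak of the compounds shown alone.

In an ADME assay on MT4 cells (Homo sapiens) for cytotoxicity, read by MTT assay, with a stated time of 5 days (on this read-out lower numbers stand for higher toxicity in this test and higher numbers for lower toxicity in this test), compound 1 `C=CCNc1cc(Oc2c(C)cc(/C=C/C#N)cc2C)nc(Nc2ccc(C#N)cc2)n1` gives 3050 nM and lies within the scatter of compound 3 `Cc1cc(/C=C/C#N)cc(C)c1Oc1cc(NCCN(C)C)nc(Nc2ccc(C#N)cc2)c1` at 4270 nM while compound 2 `Cc1cc(/C=C/C#N)cc(C)c1Oc1cc(Nc2ccc(C#N)cc2)nc(NC2CC2)c1` stands clearly higher at (24800 nM). Compound 4 `Cc1cc(/C=C/C#N)cc(C)c1Oc1cc(NCCC#N)nc(Nc2ccc(C#N)cc2)n1` differs from compound 1 by cyanomethyl in place of vinyl on a saturated chain carbon bound to a nitrogen on an aromatic ring, that is, cyanomethyl in place of vinyl on a saturated chain carbon bound to a nitrogen on an aromatic ring. Among the measured compounds shown here, the one measured step, a 5.8-fold lower number from compound 2 to compound 3 (0.76 log units; beyond the scatter) with 2-(dimethylamino)ethyl in place of cyclopropyl, involves other groups and bears only loosely on this change. No step beyond the scatter is therefore expected, only a slight upward lean, estimated as (a 1.5-fold higher number from compound 1 to compound 4 (0.17 log units; within the scatter)). Compound 4 is expected at 4500 nM within a range of 1500 nM to (15000 nM).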

Compound 4, half-maximal cytotoxic concentration: 1000 nM
The estimate for compound 4 lay 4.5-fold (0.65 log units) above the measured number, and the stated range ends above it.
By their numbers in this assay, from the lowest: compound 4; then compounds 1 and 3 (each within the scatter of the next); then compound 2.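

Putting (2-cyanoethyl)amino in place of allylamino gives a 3.1-fold lower number from compound 1 to compound 4 (0.48 log units; beyond the scatter) in this assay, a move towards higher toxicity in this test. The position therefore responds beyond the scatter to a change confined to the chain end, where cyanomethyl stands in place of vinyl. Nothing at hand gives a reason for this step. The compounds shown leave open whether the lower number follows the nitrile itself or would also appear with a hydroxyl group or a primary amide at the chain end. They also leave open how a longer chain carrying the nitrile would read.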